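The compounds below may be only part of what the source reports. "The series", "measured", "known", "first", "only" and "open" are said of these compounds alone.

In an in vivo ADME assay on the whole organism (strain 129/SvEvBrd x C57BL/6) for pharmacokinetics, with Mus musculus as the target, at a dose of 1 mg/kg by the intravenous route (a higher number here means faster removal of the compound, a lower number slower removal), compound 1 (`CC(O)c1nc([C@@H](O)[C@H](O)[C@H](O)CO)c[nH]1`) gives 16.4 mL/min/kg, compound 2 (`OC[C@@H](O)[C@@H](O)[C@H](O)c1c[nH]c(-c2ncccn2)n1`) gives 15.2 mL/min/kg and compound 3 (`OC[C@@H](O)[C@@H](O)[C@H](O)c1c[nH]c(-c2ncon2)n1`) gives 11.3 mL/min/kg. On these numbers, compound 3 is not separated from the other two. The measured steps to it are a 1.5-fold lower number from compound 1 to compound 3 (0.16 log units; within the scatter) and a 1.3-fold lower number from compound 2 to compound 3 (0.13 log units; within the scatter), and the remaining one is a 1.1-fold lower number from compound 1 to compound 2 (0.03 log units; within the scatter). Compound 4 (`Cn1cnc(-c2nc([C@@H](O)[C@H](O)[C@H](O)CO)c[nH]2)c1`) has 1-methyl-1H-imidazol-4-yl in place of the 1,2,4-oxadiazol-3-yl of compound 3, on an aromatic carbon between two ring nitrogen atoms: 1-methyl-1H-imidazol-4-yl in place of 1,2,4-oxadiazol-3-yl on an aromatic carbon. All three measured exchanges at this carbon stayed within the scatter, so no step beyond it is expected in this assay. The estimated step is a 1.2-fold higher number from compound 3 to compound 4 (0.09 log units; within the scatter). Compound 4 is expected at 14 mL/min/kg, within a range of 8 mL/min/kg to 24 mL/min/kg.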

Compound 4, clearance: 9.1 mL/min/kg
Beside the measured number, compound 4's estimate is 1.5-fold (0.19 log units) above it; the measured number falls inside the stated range.
By their numbers in this assay, from the lowest: compounds 4, 3, 2 and 1 (each within the scatter of the next).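

With 1-methyl-1H-imidazol-4-yl on the aromatic carbon between two ring nitrogen atoms, this assay gives three new steps: a 1.2-fold lower number from compound 3 to compound 4 (0.09 log units; within the scatter) and a 1.7-fold lower number from compound 2 to compound 4 (0.22 log units; within the scatter) and a 1.8-fold lower number from compound 1 to compound 4 (0.26 log units; within the scatter). A fourth group at this carbon, and the widest gap yet seen there, therefore still stays within the scatter. No measurement offered here accounts for these numbers.

Every group shown at this carbon except 1-hydroxyethyl is an aromatic ring, so how an amine, a carboxylic acid or a longer alkyl chain there would read in this assay stays open. As far as these compounds go, the group of 8 heavy atoms is the same in all four compounds, so its contribution also stays open.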